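This account rests on a few compounds, and the source may have more. Where it says the series, first, only, none or still open, it means among the compounds named here.

Measured so far in a functional assay on the whole organism (strain Wistar) for inhibition, with Rattus norvegicus as the target, read by paw edema, with a stated time of 3 h, at a dose of 10 mg/kg by the oral route; a lower number here means less inhibition, a higher number more inhibition at the dose given (going by the name of the read-out):
compound 1 `Clc1ccccc1-c1nnc(COc2ccc(-c3ccccc3)cc2)o1`, 59.1%
compound 2 `Clc1ccc(-c2nnc(COc3ccc(-c4ccccc4)cc3)o2)c(Cl)c1`, 56.1%
compound 3 `Clc1ccc(Nc2nnc(COc3ccc(-c4ccccc4)cc3)s2)cc1`, 52.3%

All three values lie within the scatter of each other; compound 3 has the lowest number but its gaps to compound 2 and compound 1 are both inside the usual spread. For the measured compounds named here, the one measured step, a number 3 percentage points lower from compound 1 to compound 2 (within the scatter), concerns a substituent on the core rather than the amino-linked ring and is itself within the scatter.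

Compound 4 `Cc1ccccc1Nc1nnc(COc2ccc(-c3ccccc3)cc2)s1` differs from compound 3 by 2-methylphenyl in place of 4-chlorophenyl on a nitrogen on an aromatic ring. Going by the values given here, no measured step touches this position, so nothing in the set argues for a shift beyond the scatter in this assay. The expectation is therefore a number 0.3 percentage points lower from compound 3 to compound 4 (within the scatter), essentially flat. Compound 4 is estimated at 52%, within 40% to 64%.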

Compound 4, a percentage reported as inhibition, in the whole organism at one dose (the size of the read-out at that dose, not a potency): 25%
The estimate for compound 4 lay 27 percentage points above the measured number; the measured number lies below the stated range.
By their numbers in this assay, from the lowest: compound 4; then compounds 3, 2 and 1 (each within the scatter of the next).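

For the compounds shown here, the group on the nitrogen is the first place where a change moves this assay beyond the scatter: a number 27.3 percentage points lower from compound 3 to compound 4 (beyond the scatter). Both groups count 7 heavy atoms and one six-membered aromatic ring, so this position responds to a swap that leaves those counts unchanged. Nothing available accounts for the drop.

Going by these compounds alone, the single step cannot separate loss of the chlorine from gain of the methyl or from the change in where the substituent sits. Unsubstituted phenyl on this nitrogen would give a reference for both compound 3 and compound 4.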